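The compounds below may be only part of what the source reports. "The series", "measured", "known", "first", "only" and "open" are said of these compounds alone.

Compound 3 `CN(O)C(=O)NCc1ncc(-c2cc(Cl)cc(F)c2-c2nnn(C)n2)cc1F` is measured in a functional assay on IMR-90 cells for antagonist activity at B1 bradykinin receptor (Homo sapiens), read by calcium flux (a higher number here means a weaker inhibitor, a lower number a stronger inhibitor), at 17 nM. Among the three compounds with numbers, compound 3 carries the highest one: compound 2 `Cc1nc(-c2c(F)cc(Cl)cc2-c2cnc([C@@H](C)NC(=O)N(C)O)c(C)c2)no1` gives 3.6 nM in this assay, and compound 1 `Cc1nc(-c2c(Cl)cc(Cl)cc2-c2cnc([C@@H](C)NC(=O)N(C)O)c(F)c2)no1` gives 2.3 nM, both lying beyond the scatter from compound 3. Compound 4 `Cn1nnc(-c2c(F)cc(Cl)cc2-c2cnc(CNC(=O)N(O)C3CCC(F)(F)CC3)c(F)c2)n1` has not yet been measured. It differs from compound 3 in one place, (4,4-difluorocyclohexyl in place of methyl on an amide-type nitrogen), that is, 4,4-difluorocyclohexyl in place of methyl on an amide-type nitrogen whose other neighbours are a carbonyl carbon and an oxygen. Within the data shown here, no pair among the measured compounds shows this change, so the data give no step to lean on for its effect in this assay. The expected step here is a 1.4-fold lower number from compound 3 to compound 4 (0.15 log units; within the scatter), a change that may as well stay within the scatter as fall beyond it in either direction. Compound 4 is therefore estimated at 12 nM, with a range from 3 nM to 50 nM.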

Compound 4, half-maximal inhibitory concentration: 0.19 nM
For compound 4 the middle estimate is 63-fold (1.80 log units) above the measured one, outside the stated range (below it).
By their numbers in this assay, from the lowest: compound 4; then compounds 1 and 2 (each within the scatter of the next); then compound 3.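

All three earlier compounds, compound 1, compound 2 and compound 3, carry methyl on the amide-type nitrogen whose other neighbours are a carbonyl carbon and an oxygen, so they gave no view of what this position tolerates. Exchanging that methyl for 4,4-difluorocyclohexyl gives an 89-fold lower number from compound 3 to compound 4 (1.95 log units; beyond the scatter) in this assay and shows that the position accepts a group of eight heavy atoms with a ring, and that the number falls steeply with it. Nothing in the data shown accounts for the size of this step.

As far as these compounds go, how a plain cyclohexyl, a cyclopropyl or an ethyl on this nitrogen would compare stays open, and with it whether the step belongs to the ring or to its two fluorines. Also open, from the compounds shown here alone, is whether the same change would carry over to the cores of compound 1 and compound 2.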